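Trifluoromethyl to fluoro on the pendant aryl

The compounds below may be only part of what the source reports. "The series", "measured", "known", "first", "only" and "open" are said of these compounds alone.

Compound 2 `CC(c1ccc(-c2ccccc2)c(F)c1)c1nnc2n1N=C(c1ccc(C(F)(F)F)cc1)CS2` holds the lowest of the two numbers recorded so far in a functional assay on MCF7 cells (Homo sapiens) for inhibition, read by sulforhodamine B assay, with a stated time of 72 h; on this read-out lower numbers stand for stronger inhibition and higher numbers for weaker inhibition. In this assay compound 2 gives 4300 nM. Compound 1 `CC(C)Cc1ccc(C(C)c2n[nH]c(=S)n2N)cc1` is built on a different core; in this assay compound 1 gives 16100 nM, a number that lies beyond the scatter above that of compound 2. For the measured compounds named here, no pair of measured compounds differing in a single place is available, so the change leading to compound 3 `CC(c1ccc(-c2ccccc2)c(F)c1)c1nnc2n1N=C(c1ccc(F)cc1)CS2` has no measured counterpart. Compound 3 differs from compound 2 by fluoro in place of trifluoromethyl on an aromatic carbon, para to a large group. Without a comparable measured step, a modest move toward a higher number is expected, a 1.6-fold higher number from compound 2 to compound 3 (0.21 log units; within the scatter), and a result within the scatter would not be surprising. Compound 3 is estimated at 7000 nM in this assay, with a range from 2500 nM to 20000 nM.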

Compound 3, half-maximal inhibitory concentration: 8100 nM
Compound 3: the middle estimate sits 1.2-fold (0.06 log units) below what was measured; the range from low to high includes it.
By their numbers in this assay, from the lowest: compounds 2, 3 and 1 (each within the scatter of the next, the first and the last beyond it).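

In this assay the series now has its first step at a single place, and the step of a 1.9-fold higher number from compound 2 to compound 3 (0.28 log units; within the scatter) leaves 4-(trifluoromethyl)phenyl and 4-fluorophenyl indistinguishable on this read-out. The position on the aromatic ring, para to a large group, therefore accepts fluoro in place of trifluoromethyl with the shared core unchanged, something compound 1, on a different core, could not show. No measurement is at hand that bears on this result.

On these data alone, whether this position stays as insensitive with a group of another kind, such as an amine, a carboxylic acid or a methoxy group, remains open. As far as these compounds go, since both groups compared here carry fluorine, the effect of hydrogen at this position also remains open.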